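A few compounds are considered here, and "the series" means these few. Any claim that something is new, unique, unknown or untested is made for them only; others in the source may bear on it.

In a functional assay on HT-29 cells (Homo sapiens) for cytotoxicity, read by XTT assay, with a stated time of 72 h (a higher number here means a weaker inhibitor, a lower number a stronger inhibitor), compound 1 `CCn1ccc2cc(C(O)c3cc(OC)c(OC)c(OC)c3)ccc21` gives > 1000 nM, which is a limit of the measurement rather than a number. Compound 2 `CCn1ccc2cc(/C(=N\OC(C)=O)c3cc(OC)c(OC)c(OC)c3)ccc21` likewise stays at the limit, giving > 1000 nM in this assay. Compound 3 `CN/N=C(/c1cc(OC)c(OC)c(OC)c1)c1ccc2c(ccn2C)c1` is the starting point here, and in this assay compound 3 also reaches only a limit, > 1000 nM. So compound 3 stands where every measured compound stands: at the limit of > 1000 nM in this assay, at which 3 of the 3 values shown sit, with nothing to separate it from the others. Compound 4 `COc1cc(/C(=N/C(=O)OC(C)(C)C)c2ccc3c(ccn3C)c2)cc(OC)c1OC` carries tert-butoxycarbonyl in place of methylamino on a double-bonded nitrogen. Within the data shown here, with no measured pair to lean on, the step from compound 3 to compound 4 is estimated as a step that the limit leaves unreadable from compound 3 to compound 4, that is, none beyond the scatter. Compound 4 is therefore expected to give about 2500 nM in this assay, within 800 nM to 12000 nM, and most likely to be reported again only as a limit.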

Compound 4, half-maximal inhibitory concentration: > 1000 nM
Compound 4 was reported as a limit; the forecaster's own chance of this, stated with the estimate: 75%; the middle value lies beyond the limit too.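

Among these compounds, compound 4 gives only a limit, as compound 3 does, so no step between compound 3 and compound 4 can be read in this assay: the limit of > 1000 nM in this assay, at which 4 of the 4 values shown sit. The compounds shown leave open whether tert-butoxycarbonyl in place of methylamino changes potency at all.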